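The compounds below may be only part of what the source reports. "The series", "measured", "known", "first", "only" and "open" are said of these compounds alone.

Measured so far in a physicochemical assay for solubility, in phosphate buffer, at pH 7.4; a higher number here means a more soluble compound, a lower number a less soluble compound:
compound 1 `CC1(C)C2CCC1(C)C(NC(=O)NCCCCNC(=O)NC1CC3CCC1(C)C3(C)C)C2` gives 10000 nM
compound 2 `CC1(C)C2CCC1(C)C(NC(=O)Nc1ccccc1F)C2` gives 225000 nM
compound 3 `CC1(C)[C@@H]2CC[C@@]1(C)C(NC(=O)Nc1ccccc1F)C2` gives 225000 nM

Compound 3 sits level with compound 2 in this assay, and together the two hold the highest of the three numbers; compound 3 stands far apart from compound 1, whose number is lower by a margin beyond the scatter. Compound 4 `CC1(C)[C@H]2CC[C@]1(C)C(NC(=O)Nc1ccccc1F)C2` keeps every atom and bond of compound 3, and the whole difference is this: the two compounds have the same atoms and bonds; at least one stereo element is drawn with a configuration in one of them and without one in the other: 2 of 3 stereo elements differ; a stereocentre at a saturated ring carbon is drawn R in compound 3 and S in compound 4; a stereocentre at a saturated ring carbon is drawn R in compound 3 and S in compound 4. Among the compounds with values here, one measured step bears on such a change because of the fact that one of compounds 2 and 3 is drawn with a defined configuration and the other without, at the place where they differ, and that step, no change at the digits printed from compound 2 to compound 3 (within the scatter), brought no movement in the number. The change to compound 4 likewise touches only how two saturated ring carbons are drawn, with nothing leaving and nothing entering. No step beyond the scatter is therefore expected in this assay for compound 4. Compound 4 is expected to give 225000 nM, with a range from 140000 nM to 360000 nM. The expected step from compound 3 is no change at the digits printed from compound 3 to compound 4 (within the scatter), that is, none beyond the scatter.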

Compound 4, solubility: 225000 nM
For compound 4 middle estimate and measured number coincide at the digits printed; measured number inside the range.
By their numbers in this assay, from the lowest: compound 1; then compounds 2, 3 and 4 (each within the scatter of the next).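

In this assay, the earlier pair set an undrawn configuration against a drawn one; here two drawn configurations are compared directly, with both saturated ring carbons going from R to S, and the result is no change at the digits printed from compound 3 to compound 4 (within the scatter). Set against the undrawn form, the reading is the same: no change at the digits printed from compound 2 to compound 4 (within the scatter). At these two ring carbons, then, neither drawn configuration separates from the other or from the undrawn form in this assay, at least with the rest of the structure held fixed.

The third stereo element stays undrawn in compounds 2, 3 and 4, so its configuration remains an open question. Also open, going by these compounds, is how the number would respond to a real change of atoms, such as an amine or a carboxylic acid in place of the fluorine.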